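The source may hold more compounds than are shown below. What is called first, only, known or untested is meant among the compounds shown, and "the series" means these compounds.

Measured so far in a physicochemical assay for solubility, read by nephelometry, measured as kinetic solubility, at pH 6.5 (a higher number here means a more soluble compound, a lower number a less soluble compound), are these compounds:

Compound 1 (`NCc1csc(NC(=O)c2ncccn2)n1`): > 100 ug/mL
Compound 2 (`CC(=O)NCc1csc(NC(=O)c2cc(C(C)(C)C)nn2Cc2ccccc2)n1`): 12.5 ug/mL
Compound 3 (`NCc1csc(NC(=O)c2cnnn2Cc2ccccc2)n1`): 50 ug/mL

Compound 1 gives > 100 ug/mL as a limit of this assay and not as a number. Of the two actual numbers, compound 2 at 12.5 ug/mL is the lower, and compound 3 at 50 ug/mL stands higher by a gap beyond the usual scatter.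

The account now turns to compound 4 (`CC(C)(C)c1cc(C(=O)Nc2nc(CNS(C)(=O)=O)cs2)n(Cc2ccccc2)n1`), which carries methylsulfonyl in place of acetyl on an amine nitrogen. Acetamidomethyl thus becomes (methanesulfonamido)methyl, and the rest of compound 2 stays as it is. Going by the values given here, no measured pair here differs in one place only, so the size of this change has no direct measure. The expectation therefore starts from compound 2 at 12.5 ug/mL and assumes little movement in either direction. The expected step of a 1.2-fold higher number from compound 2 to compound 4 (0.08 log units; within the scatter) is estimated to stay within the usual scatter. For compound 4 the estimate is 15 ug/mL with an expected range from 6 ug/mL to 40 ug/mL in this measurement.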

Compound 4, solubility: 3.1 ug/mL
Beside the measured number, compound 4's estimate is 4.8-fold (0.68 log units) above it, and the stated range ends above it.
By their numbers in this assay, from the lowest: compound 4; then compound 2; then compound 3. At a limit, above all of these: compound 1.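

In this assay, going by these compounds alone, the swap of methylsulfonyl in place of acetyl on an amine nitrogen gives a 4.0-fold lower number from compound 2 to compound 4 (0.61 log units; beyond the scatter) and so provides the first measured step between compounds that differ in one place. It shows that the number responds to what sits on this nitrogen, even though the group that leaves and the group that enters both carry no net charge and no hydrogen-bond donors. Nothing given here accounts for the direction or size of this step.

Still open, going by these compounds, is how a urea, a carbamate or a longer chain such as ethylsulfonyl on this same nitrogen would compare with acetyl and methylsulfonyl. Also open, on these data alone, is whether the swap gives a similar step on a different core, such as that of compound 3.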